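Flipping a Double Bond in a Thromboxane Receptor Antagonist

The source may hold more compounds than are shown below. What is called first, only, known or untested is meant among the compounds shown, and "the series" means these compounds.

Compound 1, with the structure `O=C(O)CCC/C=C1/C[C@H]2C[C@@H](O)[C@H](/C=N/NC(=O)Nc3ccc([N+](=O)[O-])cc3)[C@H]2C1`, is the reference point here. In a functional assay on a cell-free system (plasma) for agonist activity at thromboxane A2 receptor (Homo sapiens) (on this read-out higher numbers stand for weaker inhibition and lower numbers for stronger inhibition), compound 1 gives 50 nM, which places it second highest among the three measured compounds. Compound 2, with the structure `O=C(O)CCC/C=C1/C[C@H]2C[C@@H](O)[C@H](/C=N/NC(=O)Nc3ccccc3)[C@H]2C1`, gives 100 nM in this assay, and the step of a 2.0-fold higher number from compound 1 to compound 2 (0.30 log units; within the scatter) is too small to count as a real change. Compound 3, with the structure `O=C(O)CC/C=C1/C[C@H]2C[C@@H](O)[C@H](/C=N/NC(=O)Nc3ccc([N+](=O)[O-])cc3)[C@H]2C1`, gives 20 nM in this assay, and the step of a 2.5-fold lower number from compound 1 to compound 3 (0.40 log units; beyond the scatter) is a modest but genuine move toward stronger inhibition.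

Compound 4 has the structure `O=C(O)CCC/C=C1\C[C@H]2C[C@@H](O)[C@H](/C=N/NC(=O)Nc3ccc([N+](=O)[O-])cc3)[C@H]2C1`. Compared with compound 1, (the two compounds have the same atoms and bonds and differ only in configuration as drawn: 1 of 6 stereo elements differ; a double bond is drawn Z in compound 1 and E in compound 4). Neither measured step speaks to this kind of change: one swaps a nitro for hydrogen, the other shortens the acid chain, and both leave the double bond geometry untouched. Going by the values given here, with no comparable step to lean on, the direction and size of the shift cannot be read from the data, so the estimate is wide and centred close to the starting value. Compound 4 is therefore expected to give an estimated 150 nM in this assay, within a range from 25 nM to 1000 nM, meaning an expected step of a 3.0-fold higher number from compound 1 to compound 4 (0.48 log units; beyond the scatter).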

Compound 4, half-maximal inhibitory concentration: 60 nM
The estimate for compound 4 lay 2.5-fold (0.40 log units) above the measured number; measured number inside the range.
By their numbers in this assay, from the lowest: compound 3; then compounds 1, 4 and 2 (each within the scatter of the next).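

In this assay, turning the double bond from Z to E gives a 1.2-fold higher number from compound 1 to compound 4 (0.08 log units; within the scatter), so the geometry of this double bond leaves no readable mark on the number. The earlier steps shown here changed the nitro group and the length of the acid chain, so they could not speak to this kind of change; this pair shows that the double bond can be redrawn without a shift beyond the scatter. The reading is a clean one, since nothing else varies within the pair: the fact that compounds 1 and 4 differ only in the configuration as drawn.

As far as these compounds go, it remains open whether an E double bond would behave the same way with the shorter chain of compound 3 or without the nitro group, as in compound 2. Also open, from the compounds shown here alone, is how a methoxy group or an amine in place of the nitro group, or a longer chain carrying the acid, would read here.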